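From ureido to aminomethyl on the sulfur chain

The source may hold more compounds than are shown below. What is called first, only, known or untested is meant among the compounds shown, and "the series" means these compounds.

Of the compounds shown here, three sharing one core have been measured in a functional assay on HT cells (Homo sapiens) for antiproliferative activity, read by fluorescence, with a stated time of 72 h; a higher number here means a weaker inhibitor of growth, a lower number a stronger inhibitor of growth. Compound 1 (`CC(C)c1n[nH]c2c(NCc3ccc(-c4ccccn4)cc3)nc(SCC(O)CO)nc12`) gives 21 nM, compound 2 (`CC(C)c1n[nH]c2c(NCc3ccc(-c4ccccn4)cc3)nc(SCC(O)C(F)(F)F)nc12`) gives 690 nM, and compound 3 (`CC(C)c1n[nH]c2c(NCc3ccc(-c4ccccn4)cc3)nc(SCCNC(N)=O)nc12`) gives 240 nM. Compound 3 therefore stands in the middle of the three numbers, with an 11-fold higher number from compound 1 to compound 3 (1.06 log units; beyond the scatter) and a 2.9-fold lower number from compound 2 to compound 3 (0.46 log units; beyond the scatter).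

Compound 4 (`CC(C)c1n[nH]c2c(NCc3ccc(-c4ccccn4)cc3)nc(SCCCN)nc12`) carries aminomethyl in place of ureido on a saturated chain carbon, two bonds along the chain from a sulfur. Among the compounds with values here, no measured step makes this exact change. Within the data shown here, the measured steps show only that changes in this chain can be large, as with a 33-fold higher number from compound 1 to compound 2 (1.52 log units; beyond the scatter). Loss of ureido does not set a direction, since compound 1 lies lower than compound 3 while compound 2 lies higher. The larger gap on the side of compound 1, seen in an 11-fold higher number from compound 1 to compound 3 (1.06 log units; beyond the scatter), tentatively favours a modest move downward. The expected step is a 3.0-fold lower number from compound 3 to compound 4 (0.48 log units; beyond the scatter), with wide uncertainty. Compound 4 is estimated at 80 nM, with an expected range from 20 nM to 300 nM.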

Compound 4, concentration for 50% growth inhibition: 120 nM
For compound 4 the middle estimate is 1.5-fold (0.18 log units) below the measured one; the range from low to high includes it.
By their numbers in this assay, from the lowest: compound 1; then compounds 4 and 3 (each within the scatter of the next); then compound 2.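

In this assay, aminomethyl in place of ureido, two bonds along the chain from a sulfur, gives a 2.0-fold lower number from compound 3 to compound 4 (0.30 log units; within the scatter), so this position tolerates the exchange with no change beyond the scatter, even though the group that enters has fewer heavy atoms and hydrogen-bond donors than the one that leaves. The (3-aminopropyl)sulfanyl chain of compound 4 also places it apart from both earlier end points, with a 5.8-fold lower number from compound 2 to compound 4 (0.76 log units; beyond the scatter) and a 5.7-fold higher number from compound 1 to compound 4 (0.76 log units; beyond the scatter), so neither nitrogen-bearing chain matches the 1,2-dihydroxyethyl chain of compound 1. No experimental evidence is available to explain these steps.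

The compounds shown leave open how a dimethylamine or a carboxylic acid at the chain end would compare. They also leave open whether a longer chain carrying the same primary amine would move the number.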